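Replacing 2,4-dichlorophenyl with 3-nitrophenyl in compound 3

The source may report more compounds than this note shows. Statements on the series, on what has been measured and on what is new or still open speak of the compounds shown alone.

Compound 1 (`COC(=O)/C(=C/c1ccccc1)CN1C(=O)[C@@H](OC)[C@H]1c1ccccc1C(F)(F)F`) gives "not toxic" (no number reported)
Compound 2 (`CCOC(=O)/C(=C/c1ccccc1)CN1C(=O)[C@@H](OC)[C@H]1c1cccc([N+](=O)[O-])c1`) gives "not toxic" (no number reported)
Compound 3 (`COC(=O)/C(=C/c1ccccc1)CN1C(=O)[C@@H](OC)[C@H]1c1ccc(Cl)cc1Cl`) gives 70000 nM

Among the compounds with values here, in an ADME assay on cells (Epithelial cell, Homo sapiens) for antiproliferative activity, read by MTT assay, with a stated time of 48 h (on this read-out higher numbers stand for weaker inhibition and lower numbers for stronger inhibition), compound 3 gives 70000 nM and is the only compound with a number, while the other two have none. Compound 4 (`COC(=O)/C(=C/c1ccccc1)CN1C(=O)[C@@H](OC)[C@H]1c1cccc([N+](=O)[O-])c1`) has 3-nitrophenyl in place of 2,4-dichlorophenyl on a saturated ring carbon. Within the data shown here, no step between measured compounds is available to set the size of this change. Compound 2 also bears 3-nitrophenyl and gives "not toxic" (no number reported) in this assay so a modest move toward weaker inhibition is expected. The expected change, a 1.4-fold higher number from compound 3 to compound 4 (0.15 log units; within the scatter) is only an estimate. Compound 4 is estimated at 100000 nM with an expected range from 45000 nM to 250000 nM although it may equally be reported without a number.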

Compound 4, half-maximal inhibitory concentration: "not toxic" (no number reported)
Compound 4: no number reported, so the estimate cannot be set against anything.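

Within the data shown here, compound 4 has no number, unlike compound 3, so no step between them can be read. On these data alone, how far 3-nitrophenyl in place of 2,4-dichlorophenyl shifts inhibition remains open, and no evidence here bears on this result.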